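This account rests on a few compounds, and the source may have more. Where it says the series, first, only, none or still open, it means among the compounds named here.

The measured compounds, each with its reading in a functional assay for inhibition, with Homo sapiens as the target; on this read-out lower numbers stand for stronger inhibition and higher numbers for weaker inhibition:
Compound 1, `Cc1nc(C)n2c(S)nncc12`, gives > 48000 nM, which is a limit of the assay and not a number.
Compound 2, `COCc1nc(C)c2cnnc(S)n12`, gives > 48000 nM, again a limit and not a number.
Compound 3, `COCc1ncc2cnnc(S)n12`, gives > 48000 nM, likewise a limit.

Compound 2 therefore stands only at a limit in this assay; no measured number marks its place, and the two compounds nearest to it in structure sit at the same point, as the limit of > 48000 nM in this assay, at which 3 of the 3 values shown sit, records. The unmeasured compound 4, `Cc1ncn2c(S)nncc12`, differs from compound 2 in one place: hydrogen in place of methoxymethyl on an aromatic carbon. Within the data shown here, two measured steps bear on this change. The step from compound 1 to compound 2 adds methoxy on the saturated chain carbon at this very place and reads a step that the two limits leave unreadable from compound 1 to compound 2. The step from compound 2 to compound 3, removing a methyl from an aromatic carbon elsewhere, reads a step that the two limits leave unreadable from compound 2 to compound 3. Neither step shows any change beyond the scatter, and compound 1, which carries only a methyl where compound 4 carries hydrogen, also sits at the limit. Among the measured compounds shown here, the step from compound 2 to compound 4 in this assay is thus expected to be a step that the limit leaves unreadable from compound 2 to compound 4, that is, no step that a further measurement could tell from the scatter. Compound 4 is expected at 100000 nM, within 30000 nM to 400000 nM, and most likely only as a limit once more.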

Compound 4, half-maximal inhibitory concentration: > 48000 nM
Compound 4: only a limit was reported; the forecaster's own chance of this, stated with the estimate: 90%; the middle value lies beyond the limit too.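

In this assay compound 4 gives > 48000 nM as a limit of the assay and not a number. Compound 1 and compound 2 also stand only at limits, so neither step to compound 4 can be read. The compounds shown leave open whether any change to the shared core gives a measurable number in this assay.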